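Moving a Fluorine on a Sulfonamide Series

The source may hold more compounds than are shown below. What is called first, only, known or untested is meant among the compounds shown, and "the series" means these compounds.

Compound 3 has the structure `O=c1[nH]cc(S(=O)(=O)Nc2ccc(-c3cn(-c4ccccc4F)nn3)cc2)c(=O)[nH]1`. In a functional assay on A549 cells (Homo sapiens) for antiproliferative activity, read by MTT assay, with a stated time of 24 h (a higher number here means a weaker inhibitor, a lower number a stronger inhibitor), compound 3 gives 5960 nM, which is the second highest of the measured numbers, standing close to compound 1 and somewhat apart from compound 2. Compound 1, with the structure `O=c1[nH]cc(S(=O)(=O)Nc2ccc(-c3cn(-c4ccccc4)nn3)cc2)c(=O)[nH]1`, gives 7170 nM in this assay. Compound 2, with the structure `Cc1ccccc1-n1cc(-c2ccc(NS(=O)(=O)c3c[nH]c(=O)[nH]c3=O)cc2)nn1`, gives 3130 nM in this assay.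

Compound 4 has the structure `O=c1[nH]cc(S(=O)(=O)Nc2ccc(-c3cn(-c4ccc(F)cc4)nn3)cc2)c(=O)[nH]1`. The change from compound 3 to compound 4 is 4-fluorophenyl in place of 2-fluorophenyl on an aromatic nitrogen.

The measured steps that bear on this change are those that touch the same phenyl ring. Adding a fluorine to that ring gave a 1.2-fold lower number from compound 1 to compound 3 (0.08 log units; within the scatter), a change that stayed within the scatter. Adding a methyl instead gave a 2.3-fold lower number from compound 1 to compound 2 (0.36 log units; beyond the scatter), a modest shift. The swap of fluoro for methyl gave a 1.9-fold higher number from compound 2 to compound 3 (0.28 log units; within the scatter), again within the scatter. Among the compounds with values here, no measured step shows what moving the fluorine to another place on the ring does; since the fluorine itself barely moved the number, no step beyond the scatter is expected here.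

For compound 4 the expected step is a 1.1-fold lower number from compound 3 to compound 4 (0.03 log units; within the scatter). Compound 4 is thus estimated at 5500 nM, with a likely range from 2500 nM to 12000 nM.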

Compound 4, half-maximal inhibitory concentration: 9720 nM
Beside the measured number, compound 4's estimate is 1.8-fold (0.25 log units) below it, and the stated range covers the measured number.
By their numbers in this assay, from the lowest: compounds 2, 3, 1 and 4 (each within the scatter of the next, the first and the last beyond it).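

Swapping 2-fluorophenyl for 4-fluorophenyl on the aromatic nitrogen gives the first measured look at where the fluorine sits on this ring, and in this assay the result is a 1.6-fold higher number from compound 3 to compound 4 (0.21 log units; within the scatter), so these two placements cannot be told apart. Compound 4 also cannot be told apart from the plain phenyl of compound 1, with a 1.4-fold higher number from compound 1 to compound 4 (0.13 log units; within the scatter), which means that neither fluorine placement shown moves the number beyond the scatter relative to hydrogen. Within the data shown here, the only new step beyond the scatter is a 3.1-fold higher number from compound 2 to compound 4 (0.49 log units; beyond the scatter), a modest gap that separates the 4-fluorophenyl group from the 2-methylphenyl group of compound 2, and no supporting data here offer an explanation for it.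

The compounds shown leave open whether a methyl group would keep its modest advantage at the place the fluorine takes in 4-fluorophenyl, which would show whether the group itself or its place on the ring matters more. They also leave open what an amine or a carboxylic acid on this ring would do, since only fluoro and methyl appear there.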